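A few compounds are considered here, and "the series" means these few. Any claim that something is new, unique, unknown or untested is made for them only; others in the source may bear on it.

The series shares one core, seen in compound 1 `CC[C@@]1(c2ccccc2)OCC[C@@H](CCNCc2ccccc2)O1`, a cyclic acetal bearing an ethyl group and a phenyl ring at one ring carbon and a chain ending in a benzylamine at another. In an assay on brain for displacement of a labelled ligand from Sigma non-opioid intracellular receptor 1 (Cavia porcellus) (a higher number here means a weaker inhibitor, a lower number a stronger inhibitor), compound 1 gives 20 nM. Compound 2 `C[C@]1(c2ccccc2)OCC[C@H](CCNCc2ccccc2)O1`, which carries a methyl group in place of the ethyl and is drawn in the opposite configuration, gives 11 nM in this assay; the two numbers lie within the scatter of each other, so compound 1 stands on the higher of two numbers without a real difference between them. Compound 3 `CC(C)(C)[C@]1(c2ccccc2)OCC[C@H](CCN)O1`, with a tert-butyl group and a primary amine instead of the benzylamine, reaches only the limit of this assay, > 10000 nM, and that is a limit and not a number (the limit of > 10000 nM in this assay, at which 1 of the 3 values shown sits).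

Compound 4 `CC[C@]1(c2ccccc2)OCC[C@H](CCNCc2ccccc2)O1` is the mirror image of compound 1: the two compounds have the same atoms and bonds and differ only in configuration as drawn: 2 of 2 stereo elements differ (all stereocentres are inverted: mirror images); a stereocentre at a saturated ring carbon is drawn R in compound 1 and S in compound 4; a stereocentre at a saturated ring carbon is drawn R in compound 1 and S in compound 4. Among the compounds with values here, no measured pair in this set isolates such an inversion. Compound 2, which is drawn in the same configuration as compound 4, gives a potent value in this assay. For compound 4 the expected step is no change at the digits printed from compound 1 to compound 4 (within the scatter). Compound 4 is therefore estimated at 20 nM, between 5 nM and 100 nM.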

Compound 4, inhibition constant: 28 nM
The estimate for compound 4 lay 1.4-fold (0.15 log units) below the measured number, within the range that was stated.
By their numbers in this assay, from the lowest: compounds 2, 1 and 4 (each within the scatter of the next, the first and the last beyond it). At a limit, above all of these: compound 3.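

Inverting both stereocentres gives a 1.4-fold higher number from compound 1 to compound 4 (0.15 log units; within the scatter) in this assay, so with the ethyl group the two mirror-image forms show no real separation, and configuration is isolated here for the first time: the fact that compounds 1 and 4 differ only in the configuration as drawn. Methyl in place of hydrogen on a saturated chain carbon bound to a saturated ring carbon gives a 2.5-fold higher number from compound 2 to compound 4 (0.41 log units; beyond the scatter), the first single-place step in this set to lie beyond the scatter. The shared configuration of this pair means that the step can be read at this position without any change in configuration, although it rests on this one pair alone.

The compounds shown leave open whether a propyl or cyclopropyl group at this position would continue the step, and whether inverting just one of the two stereocentres would matter as little as inverting both. They also leave open what a phenethyl group on the amine would do, and compound 3, which stands at a limit of the assay at > 10000 nM, differs from the others in more than one place and cannot settle the role of the benzyl group.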